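A few compounds are considered here, and "the series" means these few. Any claim that something is new, unique, unknown or untested is made for them only; others in the source may bear on it.

Working notes on the series. Among the measured compounds shown here, the three measured members share one core: compound 1 is `Cc1cccc(C)c1NC(=O)CSc1nnc(-c2ccoc2C)n1Cc1ccco1`, compound 2 is `Cc1cccc(NC(=O)CSc2nnc(-c3ccoc3C)n2Cc2ccco2)c1C` and compound 3 is `COc1ccc(C)cc1NC(=O)CSc1nnc(-c2ccoc2C)n1Cc1ccco1`. In a functional assay on CHO cells for antagonist activity at Orexin/Hypocretin receptor type 1 (Homo sapiens), read by FLIPR and calcium flux (on this read-out higher numbers stand for weaker inhibition and lower numbers for stronger inhibition), compound 1 gives only a limit, > 15800 nM. Compound 2 likewise reaches only a limit in this assay, > 15800 nM. For the measured compounds named here, compound 3 gives a number in this assay, 2510 nM, the only number among the three. Compound 1 and compound 2 sit at a limit, as the limit of > 15800 nM in this assay, at which 2 of the 3 values shown sit, records. The step of an at least 6.2-fold lower number from compound 1 to compound 3 (0.79 log units; beyond the scatter) and the step of an at least 6.2-fold lower number from compound 2 to compound 3 (0.79 log units; beyond the scatter) are both at least modest, while the step that the two limits leave unreadable from compound 1 to compound 2 the two limits leave unreadable.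

Compound 4 is `Cc1occc1-c1nnc(SCC(=O)Nc2ccc(F)c(Cl)c2)n1Cc1ccco1`. The change from compound 3 is 3-chloro-4-fluorophenyl in place of 2-methoxy-5-methylphenyl on an amide-type nitrogen. Going by the values given here, no measured step removes the methoxy group while introducing halogens, so the two readable steps bear only indirectly: they show that the substitution pattern of the ring on the amide-type nitrogen moves this assay by at least a modest amount. For compound 4 a step of a 2.4-fold higher number from compound 3 to compound 4 (0.38 log units; beyond the scatter) toward a higher number is expected. Among the compounds with values here, compound 3, carrying the 2-methoxy-5-methylphenyl ring, is the only member with a number, 2510 nM. Compound 4 is estimated at 6000 nM in this assay, within 1500 nM to 20000 nM.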

Compound 4, inhibition constant: 1000 nM
Compound 4: middle estimate off by 6.0-fold (0.78 log units), on the high side; measured number outside the range, below it.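

In this assay, the 2-methoxy-5-methylphenyl ring is not needed for a measurable number: replacing it with 3-chloro-4-fluorophenyl, which has no hydrogen-bond acceptor, gives a 2.5-fold lower number from compound 3 to compound 4 (0.40 log units; beyond the scatter). Against the two dimethylphenyl rings, the same ring gives an at least 15-fold lower number from compound 2 to compound 4 (1.19 log units; beyond the scatter) and an at least 15-fold lower number from compound 1 to compound 4 (1.19 log units; beyond the scatter), so this position spans a wider range than compound 3 alone indicated. Both of these larger steps are read against limits, those of compound 1 and compound 2, so their true size stays open: the limit of > 15800 nM in this assay, at which 2 of the 4 values shown sit.

On these data alone, the chlorine and the fluorine enter together, so the share of each in the step stays open. Also open, as far as these compounds go, is how this position would read with a nitrile or a carboxylic acid on the ring, or with a longer chain in place of the ring.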